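The compounds below may be only part of what the source reports. "The series", "measured", "known", "first", "only" and "open" are said of these compounds alone.

Compound 1 `Cc1cc(Nc2cc(-c3ccccc3)[nH]n2)n2nc(SCc3ccc([N+](=O)[O-])cc3)nc2n1` gives 7980 nM in a functional assay on PC-9 cells (Homo sapiens) for inhibition, read by MTT assay, with a stated time of 72 h; a lower number here means a stronger inhibitor, a higher number a weaker inhibitor. Compound 2 `Cc1cc(Nc2cc(-c3ccccc3)[nH]n2)n2ncnc2n1` reaches only the limit of > 50000 nM in this assay, a limit and not a number. Compound 3 `Cc1cc(Nc2cc(-c3ccccc3)[nH]n2)n2nc(SCc3c(Cl)cccc3Cl)nc2n1` gives 5180 nM in this assay. Compound 4 `Cc1cc(Nc2cc(-c3ccccc3)[nH]n2)n2nc(SCc3csc4ccccc34)nc2n1` has not yet been measured.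

Among the two numbers, compound 1 stands highest, with compound 3 nearest: a 1.5-fold lower number from compound 1 to compound 3 (0.19 log units; within the scatter). Removing the whole side group gives an at least 6.2-fold higher number from compound 1 to compound 2 (0.79 log units; beyond the scatter), where the limit of > 50000 nM in this assay, at which 1 of the 3 values shown sits, applies.

Compound 4 differs from compound 1 in one place: 1-benzothiophen-3-yl in place of 4-nitrophenyl on a saturated chain carbon bound to a sulfur. Within the data shown here, the step that bears on this is the one from compound 1 to compound 3, where the aryl on the saturated chain carbon bound to a sulfur was exchanged and the result was a 1.5-fold lower number from compound 1 to compound 3 (0.19 log units; within the scatter). Keeping the benzylsulfanyl-type side group intact while changing its aryl therefore points to no step beyond the scatter in this assay, perhaps a slight lowering. Compound 4 is expected to give 5500 nM, between 2500 nM and 12000 nM. The step expected here is a 1.5-fold lower number from compound 1 to compound 4 (0.16 log units; within the scatter).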

Compound 4, half-maximal inhibitory concentration: 4420 nM
Estimate against measurement, compound 4: 1.2-fold (0.09 log units) above; measured number inside the range.
By their numbers in this assay, from the lowest: compounds 4, 3 and 1 (each within the scatter of the next). At a limit, above all of these: compound 2.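

The position takes a third aryl, 1-benzothiophen-3-yl, which brings a five-membered aromatic ring, with no step beyond the scatter from either earlier aryl (a 1.8-fold lower number from compound 1 to compound 4 (0.26 log units; within the scatter)) and (a 1.2-fold lower number from compound 3 to compound 4 (0.07 log units; within the scatter)). Compound 1, compound 3 and compound 4 thus stay within the scatter of one another in this assay, across three differently built aryl groups on the saturated chain carbon bound to a sulfur. The step from the hydrogen of compound 2 now holds for this third side group as well (an at least 11-fold lower number from compound 2 to compound 4 (1.05 log units; beyond the scatter)), and it rests on a limit for compound 2, not on a number: (the limit of > 50000 nM in this assay, at which 1 of the 4 values shown sits).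

Going by these compounds, it remains open whether the aryl is needed at all, or whether a plain methylsulfanyl group would serve as well. Equally open, on these data alone, is how an amine or a carboxylic acid on the aryl, or a longer chain to the sulfur, would read in this assay.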